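Bromobenzyl sulfide paired with the unsubstituted phenyl pyrazole

The compounds below may be only part of what the source reports. "The series", "measured", "known", "first", "only" and "open" are said of these compounds alone.

Working notes on the series. Three compounds have numbers in a functional assay on PC-9 cells (Homo sapiens) for inhibition, read by MTT assay, with a stated time of 72 h; a lower number here means a stronger inhibitor, a higher number a weaker inhibitor: compound 1 `Cc1cc(Nc2cc(-c3ccccc3)[nH]n2)n2nc(SCc3c(Cl)cccc3Cl)nc2n1`, compound 2 `Cc1cc(Nc2cc(-c3ccc(Cl)cc3)[nH]n2)n2nc(SCc3ccc(Br)cc3)nc2n1` and compound 3 `Cc1cc(Nc2cc(-c3ccccc3)[nH]n2)n2nc(SCc3nc4ccccc4[nH]3)nc2n1`. In this assay compound 1 gives 5180 nM, compound 2 gives 4920 nM and compound 3 gives 4840 nM. Compound 3 carries the lowest of the three numbers, yet its separation from each of the other two is within the scatter, so the three stand together and no order among them can be read.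

Compound 4 `Cc1cc(Nc2cc(-c3ccccc3)[nH]n2)n2nc(SCc3ccc(Br)cc3)nc2n1` has not been measured in this assay. It differs from compound 3 in one place: 4-bromophenyl in place of 1H-benzimidazol-2-yl on a saturated chain carbon bound to a sulfur. Among the compounds with values here, one measured step bears on this directly, a 1.1-fold lower number from compound 1 to compound 3 (0.03 log units; within the scatter), which exchanged a group at the same place and stayed within the scatter. Compound 2 carries the 4-bromobenzyl group as well, and its value of 4920 nM lies within the scatter of the values of compound 1 and compound 3. Nothing here points to a shift beyond the scatter in either direction. Compound 4 is therefore expected to show an estimated step of a 1.0-fold higher number from compound 3 to compound 4 (0.01 log units; within the scatter). The estimate for compound 4 in this assay is 5000 nM, with an expected range from 2500 nM to 10000 nM.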

Compound 4, half-maximal inhibitory concentration: 4760 nM
For compound 4 the middle estimate is 1.1-fold (0.02 log units) above the measured one; the measured number falls inside the stated range.
By their numbers in this assay, from the lowest: compounds 4, 3, 2 and 1 (each within the scatter of the next).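

In this assay, the three groups on a saturated chain carbon bound to a sulfur can now be compared in every pairing: 4-bromophenyl gives a 1.0-fold lower number from compound 3 to compound 4 (0.01 log units; within the scatter) and a 1.1-fold lower number from compound 1 to compound 4 (0.04 log units; within the scatter), which join a 1.1-fold lower number from compound 1 to compound 3 (0.03 log units; within the scatter), and all three steps lie within the scatter. The 1H-benzimidazol-2-yl group counts a hydrogen-bond donor and acceptor and 4-bromophenyl counts neither, yet this exchange gives no separation in this series. The series also gains its first step at a second place, hydrogen in place of chloro on an aromatic carbon, and a 1.0-fold lower number from compound 2 to compound 4 (0.01 log units; within the scatter) likewise stays within the scatter. No supporting measurement accounts for these results.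

The compounds shown leave open whether an aliphatic amine, a carboxylic acid or a longer chain on the carbon bound to the sulfur would move the number beyond the scatter. They also leave open whether methoxy or trifluoromethyl in place of the chloro on the aromatic carbon would separate from the values seen so far.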